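A few compounds are considered here, and "the series" means these few. Any claim that something is new, unique, unknown or untested is made for them only; others in the source may bear on it.

Compound 1 `CNC(=O)c1cc(Oc2ccc(NC(=O)c3cc(-c4ccc(F)cc4)ncn3)cc2)ccn1` gives only a limit of the assay, > 100000 nM.
Compound 2 `CCc1ccc(-c2cc(C(=O)Nc3ccc(Oc4ccnc(C(=O)NC)c4)cc3)ncn2)cc1` gives 6350 nM in a functional assay on MCF7 cells (Homo sapiens) for cytotoxicity, read by MTT assay, with a stated time of 72 h; a higher number here means a weaker inhibitor, a lower number a stronger inhibitor.

Compound 2 thus holds the only real number shown; the other value is a limit (the limit of > 100000 nM in this assay, at which 1 of the 2 values shown sits). Compound 3 `CNC(=O)c1cc(Oc2ccc(NC(=O)c3cc(-c4ccc(Br)cc4)ncn3)cc2)ccn1` differs from compound 2 by bromo in place of ethyl on an aromatic carbon. For the measured compounds named here, the one measured step, an at least 15-fold lower number from compound 1 to compound 2 (1.19 log units; beyond the scatter), bears on this change, since fluoro and bromo are each a single heavy atom in that position. A move back toward weaker inhibition is therefore expected, though with wide uncertainty. Compound 3 is expected to give 20000 nM, within 5000 nM to 100000 nM. The expected step is a 3.1-fold higher number from compound 2 to compound 3 (0.50 log units; beyond the scatter).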

Compound 3, half-maximal inhibitory concentration: > 100000 nM
Compound 3: no number, only a limit; the forecaster's own chance of this, stated with the estimate: 30%; middle value at least 5.0-fold (0.69 log units) away from the limit.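

Replacing 4-ethylphenyl with 4-bromophenyl gives, in this assay, an at least 15-fold higher number from compound 2 to compound 3 (1.19 log units; beyond the scatter), so the weak result is not confined to fluoro. Of the compounds shown, only the one carrying ethyl gives a real number, while both halogen compounds end at a limit: the limit of > 100000 nM in this assay, at which 2 of the 3 values shown sit. The step from compound 1 to compound 3 cannot be read, as both values are limits.

Going by these compounds, whether ethyl itself matters, or any small carbon group would serve, remains open. A methyl group, a longer chain such as propyl, or an amine at this place could begin to separate these possibilities.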